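This account rests on a few compounds, and the source may have more. Where it says the series, first, only, none or still open, it means among the compounds named here.

Measured so far in a functional assay on MCF7 cells (Homo sapiens) for antiproliferative activity, read by MTT assay (a higher number here means a weaker inhibitor, a lower number a stronger inhibitor), are
- compound 1 `COc1cc2c(Oc3ccc(NC(=O)Nc4ccccc4C(F)(F)F)cc3)ccnc2cc1OCCCCCCC(=O)NO` with 1080 nM
- compound 2 `COc1cc2c(Oc3ccc(NC(=O)Nc4ccc(C(F)(F)F)cc4Cl)cc3)ccnc2cc1OCCCCCCC(=O)NO` with 500 nM
- compound 3 `COc1cc2c(Oc3ccc(NC(=O)Nc4ccc(C)cc4C)cc3)ccnc2cc1OCCCCCCC(=O)NO` with 3430 nM

Compound 3 holds the highest number of the three, with a 3.2-fold higher number from compound 1 to compound 3 (0.50 log units; beyond the scatter) and a 6.9-fold higher number from compound 2 to compound 3 (0.84 log units; beyond the scatter) as the steps that lead to it. Within the data shown here, compound 4 `COc1cc2c(Oc3ccc(NC(=O)NC4CCCCC4)cc3)ccnc2cc1OCCCCCCC(=O)NO` carries cyclohexyl in place of 2,4-dimethylphenyl on an amide-type nitrogen as its only change. The measured steps, including a 2.2-fold lower number from compound 1 to compound 2 (0.33 log units; beyond the scatter) as the third, all exchange one substituted phenyl for another. None replaces an aromatic ring with a non-aromatic one, so they give a rough size and no direction. No step beyond the scatter is expected in this assay, although a modest one either way remains possible. The expected step is a 1.2-fold lower number from compound 3 to compound 4 (0.09 log units; within the scatter) on this estimate. For compound 4 the estimate is 2800 nM with an expected range from 900 nM to 8000 nM for repeated measurements.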

Compound 4, half-maximal inhibitory concentration: 600 nM
The estimate for compound 4 lay 4.7-fold (0.67 log units) above the measured number, and the stated range ends above it.
By their numbers in this assay, from the lowest: compounds 2, 4 and 1 (each within the scatter of the next, the first and the last beyond it); then compound 3.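

In this assay, a non-aromatic ring is accepted on this amide-type nitrogen: cyclohexyl replacing 2,4-dimethylphenyl gives a clear gain (a 5.7-fold lower number from compound 3 to compound 4 (0.76 log units; beyond the scatter)). Compound 4 also stands within the scatter of both phenyl ureas bearing halogen substituents (a 1.2-fold higher number from compound 2 to compound 4 (0.08 log units; within the scatter); a 1.8-fold lower number from compound 1 to compound 4 (0.26 log units; within the scatter)), so an aromatic ring is not required here, and only compound 3 sits apart. No evidence on hand explains this step.

Still open, from the compounds shown here alone, is whether any ring is needed here, as a straight hexyl chain would test. A piperidin-4-yl ring would show whether a ring amine is accepted in this place.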